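Two halogens on the benzamide ring replace a methyl

This account rests on a few compounds, and the source may have more. Where it says the series, first, only, none or still open, it means among the compounds named here.

Three amides on one shared core have been tested in a functional assay on HepG2 cells (Homo sapiens) for antiproliferative activity, read by CCK-8 assay, with a stated time of 72 h; a lower number here means a stronger inhibitor, a higher number a weaker inhibitor. Compound 1 `O=C(Nc1cccc(-c2oc3cc(-c4ccc(F)cc4)ccc3c(=O)c2O)c1)c1ccc(F)cc1` carries a 4-fluorophenyl on the carbonyl carbon and gives 9280 nM. Compound 2 `Cc1ccccc1C(=O)Nc1cccc(-c2oc3cc(-c4ccc(F)cc4)ccc3c(=O)c2O)c1`, with a 2-methylphenyl in that place, gives 19400 nM, while compound 3 `Cc1cccc(C(=O)Nc2cccc(-c3oc4cc(-c5ccc(F)cc5)ccc4c(=O)c3O)c2)c1`, with a 3-methylphenyl, gives 13500 nM. Compound 3 therefore holds the second highest of the three numbers; its nearest neighbour is compound 2, the gap being a 1.4-fold lower number from compound 2 to compound 3 (0.16 log units; within the scatter), and its furthest is compound 1, the gap being a 1.5-fold higher number from compound 1 to compound 3 (0.16 log units; within the scatter). The only step among these three that clears the scatter is a 2.1-fold higher number from compound 1 to compound 2 (0.32 log units; beyond the scatter).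

Compound 4 `O=C(Nc1cccc(-c2oc3cc(-c4ccc(F)cc4)ccc3c(=O)c2O)c1)c1ccc(Br)cc1F` awaits measurement. Against compound 3 it differs in a single place: 4-bromo-2-fluorophenyl in place of 3-methylphenyl on a carbonyl carbon. Among the compounds with values here, no measured step exchanges a methylphenyl for a dihalogenated phenyl, so the known steps bear on it only loosely: a halogen-bearing ring in compound 1 sits at the low end, whereas a 2-substituted ring in compound 2 sits at the high end, and compound 4 carries both features. A step near the scatter, leaning slightly lower, is therefore expected, giving a 1.2-fold lower number from compound 3 to compound 4 (0.09 log units; within the scatter). For compound 4 the estimate is 11000 nM, within a range from 4000 nM to 30000 nM.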

Compound 4, half-maximal inhibitory concentration: > 100000 nM
Compound 4: no number, only a limit; the forecaster's own chance of this, stated with the estimate: 5%; at least 9.0-fold (0.95 log units) between middle value and limit.
By their numbers in this assay, from the lowest: compounds 1, 3 and 2 (each within the scatter of the next, the first and the last beyond it). At a limit, above all of these: compound 4.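

In this assay, compounds 1, 2 and 3 had shown this position on the carbonyl carbon to be fairly forgiving, the widest step among them being a 2.1-fold higher number from compound 1 to compound 2 (0.32 log units; beyond the scatter). With 4-bromo-2-fluorophenyl in that place the steps are far larger: an at least 7.4-fold higher number from compound 3 to compound 4 (0.86 log units; beyond the scatter), an at least 5.1-fold higher number from compound 2 to compound 4 (0.71 log units; beyond the scatter) and an at least 10-fold higher number from compound 1 to compound 4 (1.03 log units; beyond the scatter), and the last of these shows that a halogen on this ring does not in itself bring such a loss, since compound 1 also carries fluorine there and has the lowest number of the set. The reading for compound 4 is a limit and not a number, so these steps give only the least size of the change: the limit of > 100000 nM in this assay, at which 1 of the 4 values shown sits.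

A 4-bromophenyl or a 2-fluorophenyl on this carbonyl carbon would be needed to tell whether the bromine, the fluorine or the pair of them goes with the change. On these data alone, how a ring carrying an amine or a carboxylic acid would read in this assay also stays open.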